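Swapping fluoro for bromo in the carbonyl series

This account rests on a few compounds, and the source may have more. Where it says the series, first, only, none or still open, it means among the compounds named here.

Measured compounds:
compound 1, `COc1cc(N(Cc2nc3ccccc3[nH]2)S(=O)(=O)c2ccc(F)cc2)cc(OC)c1OC`: 9380 nM
compound 2, `COc1cc(N(Cc2nc3ccccc3[nH]2)S(=O)(=O)c2ccc(Br)cc2)cc(OC)c1OC`: 7740 nM
compound 3, `COc1cc(N(Cc2nc3ccccc3[nH]2)C(=O)c2ccc(F)cc2)cc(OC)c1OC`: 45200 nM

Of the compounds shown here, three have been tested in a functional assay on MCF7 cells (Homo sapiens) for inhibition, read by MTT assay, with a stated time of 48 h; on this read-out lower numbers stand for stronger inhibition and higher numbers for weaker inhibition. Compounds 1 and 2 share one core and differ only in bromo in place of fluoro on an aromatic carbon, a change that gave a 1.2-fold lower number from compound 1 to compound 2 (0.08 log units; within the scatter). Compound 3 carries a different core: relative to compound 1 it has (4-fluorophenyl)carbonyl in place of (4-fluorophenyl)sulfonyl on a nitrogen on an aromatic ring, and that exchange cost potency, with a 4.8-fold higher number from compound 1 to compound 3 (0.68 log units; beyond the scatter) and, seen from compound 2, a 5.8-fold higher number from compound 2 to compound 3 (0.77 log units; beyond the scatter). Compound 3 therefore gives the highest number of the three.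

Compound 4, `COc1cc(N(Cc2nc3ccccc3[nH]2)C(=O)c2ccc(Br)cc2)cc(OC)c1OC`, has not yet been measured. It differs from compound 3 by bromo in place of fluoro on an aromatic carbon, which is the same change that turns compound 1 into compound 2, here made on the carbonyl core instead of the sulfonyl core. Because that change gave only a 1.2-fold lower number from compound 1 to compound 2 (0.08 log units; within the scatter) on the first core, the expectation is that compound 4 will sit close to compound 3, with the step from compound 3 to compound 4 estimated as a 1.2-fold lower number from compound 3 to compound 4 (0.08 log units; within the scatter). Compound 4 is thus expected to come out near 38000 nM, with a likely spread from 15000 nM to 95000 nM. Whether the carbonyl core answers the halogen swap the way the sulfonyl core did remains to be seen from a single new measurement.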

Compound 4, half-maximal inhibitory concentration: > 50000 nM
Compound 4: a limit, no number (the forecaster's own chance of this, stated with the estimate: 12%); at least 1.3-fold (0.11 log units) between middle value and limit.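

In this assay compound 4 gives > 50000 nM, which is a limit of the assay and not a number: the limit of > 50000 nM in this assay, at which 1 of the 4 values shown sits. On the carbonyl core, bromo in place of fluoro gives an at least 1.1-fold higher number from compound 3 to compound 4 (0.04 log units; that floor lies within the scatter), which is only a floor and not the full size of the step, so this result neither shows that the swap carries over from the sulfonyl core unchanged nor shows that it behaves differently there: the same change on two cores in this assay, a 1.2-fold lower number (0.08 log units; within the scatter) from compound 1 to compound 2 and an at least 1.1-fold higher number (0.04 log units; that floor lies within the scatter) from compound 3 to compound 4; the limit leaves it open whether they differ. What the result does show is that compound 4 stays on the weak side of both sulfonyl compounds, with an at least 6.4-fold higher number from compound 2 to compound 4 (0.81 log units; beyond the scatter) and an at least 5.3-fold higher number from compound 1 to compound 4 (0.72 log units; beyond the scatter), the same direction in which compound 3 lies from compound 1 and compound 2.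

The compounds shown carry only fluoro and bromo at this place on the ring, so they leave open how chloro, methoxy or an amine there would read on either core. They also leave open the true size of every step that ends at compound 4, since a limit gives only a floor for each of them.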